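Series notes: aryl variation, step from compound 2 to compound 3

A few compounds are considered here, and "the series" means these few. Any claim that something is new, unique, unknown or untested is made for them only; others in the source may bear on it.

Measured compounds:
compound 1, `COc1cc(OC)c(OC)cc1/C=C/COC(=O)/C=C/c1ccc(OC)c(OC)c1`: 100%
compound 2, `COc1cc(OC)c(OC)cc1/C=C/COC(=O)/C=C/c1cccc(Br)c1`: 100%

Of the compounds shown here, two of the shared core have been measured in a functional assay on the whole organism (strain Kunming) with Mus musculus as the target, with a stated time of 0.5 h, at a dose of 300 mg/kg by the intraperitoneal route; a lower number here means a stronger effect, a higher number a weaker effect of the compound at the dose given. In this assay compound 1 gives 100%. In this assay compound 2 gives 100%. Among the measured compounds shown here, the one step between them, no change at the digits printed from compound 1 to compound 2 (within the scatter), shows that exchanging 3,4-dimethoxyphenyl for 3-bromophenyl on a double-bonded chain carbon bound to a double-bonded chain carbon left the read-out unchanged within the scatter. Compound 2 therefore stands level with compound 1 at the digits shown, with no measured neighbour that separates from it.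

Compound 3, `COc1cc(OC)c(OC)cc1/C=C/COC(=O)/C=C/c1ccccc1Cl`, is not yet measured. Relative to compound 2 the change is 2-chlorophenyl in place of 3-bromophenyl on a double-bonded chain carbon bound to a double-bonded chain carbon. For the measured compounds named here, only the step from compound 1 to compound 2 bears on this change; it altered the same aryl group at the same place and produced no change within the scatter. With no step beyond the scatter anywhere in the series, the expectation for the step to compound 3 is no change at the digits printed from compound 2 to compound 3 (within the scatter), that is, none beyond the scatter. Compound 3 is accordingly estimated to give 100% in this assay, within a range from 80% to 100%.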

Compound 3, a percentage reported as activity, at one dose (the size of the read-out at that dose, not a potency): 100%
Compound 3: the middle estimate sits on the measured number at the digits printed; the range from low to high includes it.
By their numbers in this assay, from the lowest: compounds 1, 2 and 3 (each within the scatter of the next).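

The exchange of 3-bromophenyl for 2-chlorophenyl on a double-bonded chain carbon bound to a double-bonded chain carbon gives, in this assay, no change at the digits printed from compound 2 to compound 3 (within the scatter), so a second aryl exchange at this place fails to separate two compounds, this time with chlorine in place of bromine and a differently named halophenyl group. Set against the dimethoxylated aryl group, the new group gives no change at the digits printed from compound 1 to compound 3 (within the scatter), and compound 3 stands at 100%, so the three aryl groups shown at this place do not differ in this assay. No measurement offered here bears on this result.

With no step beyond the scatter at this place, the series does not yet show whether the aryl group can move the read-out at all, and the link between any aryl feature and the effect at the dose given remains unread. Still open, going by these compounds, is whether a phenyl group carrying an amine or a carboxylic acid, or a longer chain in place of the ethenyl link, would separate from compound 3 in this assay.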